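Amide aryl variation at the carbonyl carbon

The compounds below may be only part of what the source reports. "The series", "measured", "known", "first", "only" and "open" are said of these compounds alone.

Compound 1 `Cc1ccc(S(=O)(=O)NCc2ccc(CNC(=O)c3ccncc3)cc2)cc1`: 10 nM
Compound 2 `COc1ccccc1C(=O)NCc1ccc(CNS(=O)(=O)c2ccc(C)cc2)cc1`: 100 nM

In an assay on MDA-MB-231 cells for binding affinity to C-X-C chemokine receptor type 4 (Homo sapiens), read by immunofluorescence and microscopy, with stated times of 10 min and 30 min (on this read-out higher numbers stand for an effect only at larger amounts of compound and lower numbers for an effect already at smaller amounts), compound 1 gives 10 nM and compound 2 gives 100 nM, the highest of the two numbers, with compound 1 the nearest. Compound 3 `Cc1ccc(C(=O)NCc2ccc(CNS(=O)(=O)c3ccc(C)cc3)cc2)cc1` carries the change (4-methylphenyl in place of 2-methoxyphenyl on a carbonyl carbon). Among the measured compounds shown here, the only step at this position is a 10-fold higher number from compound 1 to compound 2 (1.00 log units; beyond the scatter), which swapped a different pair of groups, so no direct precedent exists. A step of a 1.4-fold lower number from compound 2 to compound 3 (0.15 log units; within the scatter) within the scatter is expected. Compound 3 is estimated at 70 nM, between 20 nM and 300 nM.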

Compound 3, effective concentration (reported as EC, without a stated level of effect): 1000 nM
The estimate for compound 3 lay 14-fold (1.15 log units) below the measured number; measured number outside the range, above it.
By their numbers in this assay, from the lowest: compound 1; then compound 2; then compound 3.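

Replacing 2-methoxyphenyl with 4-methylphenyl on a carbonyl carbon is not a silent swap in this assay and gives a 10-fold higher number from compound 2 to compound 3 (1.00 log units; beyond the scatter) even though both groups hold a six-membered aromatic ring of carbon only. Replacing pyridin-4-yl with 4-methylphenyl at the same place gives a 100-fold higher number from compound 1 to compound 3 (2.00 log units; beyond the scatter) and widens the range seen at this position. Nothing at hand accounts for either step.

The change alters both the substituent and its place on the ring, and these remain unseparated. As far as these compounds go, whether 4-methoxyphenyl, 2-methylphenyl or pyridin-3-yl would sit closer to compound 1 or compound 3 stays open.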